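This account rests on a few compounds, and the source may have more. Where it says the series, first, only, none or still open, it means among the compounds named here.

Three compounds have so far been measured in an assay on isolated protein for inhibition of 2-Hydroxyacid oxidase 2 (Homo sapiens), tested at 1 uM; a higher number here means a stronger effect of the compound at the concentration tested, a lower number a weaker effect:

compound 1 `Cc1n[nH]c(C(=O)O)c1Cc1cccc(C(F)(F)F)c1`: 5%
compound 2 `Cc1n[nH]c(C(=O)O)c1Cc1cccc2ccccc12`: 22%
compound 3 `Cc1n[nH]c(C(=O)O)c1Cc1ccc(-c2ccc(OC(F)(F)F)cc2)cc1`: 11%

All three share the same core and differ only in the aromatic group attached to it. Compound 1 carries the lowest of the three numbers. Its gap to compound 3 lies within the usual scatter of repeated measurements, so the two cannot be told apart on these data, while its gap to compound 2 lies beyond the scatter, so compound 2 gives the clearly larger read-out in this assay.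

The next compound, compound 4 `Cc1n[nH]c(C(=O)O)c1Cc1cccc(C#N)c1`, keeps the core and the aromatic ring of compound 1 and changes one group: cyano in place of trifluoromethyl on an aromatic carbon. For the measured compounds named here, no pair of measured compounds shows this kind of exchange, so nothing in the measured set tells how large such a step is or which way it goes. Going by the values given here, the starting point is a small read-out, and with no matching precedent the plainest expectation is a step that stays within the scatter, in either direction. The step from compound 1 to compound 4 in this assay is therefore expected to be small, a number 3 percentage points higher from compound 1 to compound 4 (within the scatter). For compound 4 the estimated read-out is 8%, with a range from 0% to 20%.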

Compound 4, a percentage reported as inhibition, at one concentration (the size of the read-out at that concentration, not a potency): 6%
Beside the measured number, compound 4's estimate is 2 percentage points above it, within the range that was stated.
By their numbers in this assay, from the lowest: compounds 1, 4 and 3 (each within the scatter of the next); then compound 2.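

In this assay, for the compounds shown here, the exchange of trifluoromethyl for cyano gives the first step in this set between compounds that differ in one place: a number 1 percentage points higher from compound 1 to compound 4 (within the scatter). On this aromatic carbon, meta to a large group, the two groups cannot be told apart by this read-out, even though the entering cyano has fewer heavy atoms than the leaving trifluoromethyl and, unlike it, counts as a hydrogen-bond acceptor. No measurement at hand bears on why the two compounds read alike.

Going by these compounds, whether another kind of group on the same aromatic carbon, such as an amine, a hydroxyl group or a carboxylic acid, would give a step beyond the scatter remains open, since this single exchange says nothing about groups other than these two. Also open, on these data alone, is whether cyano in place of trifluoromethyl would give a similar step on a different carbon of the ring or on a compound with a different aromatic group, as this one pair offers a reading at a single place only.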